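Methyl to trifluoromethyl on the aromatic ring: compound 4

The source may report more compounds than this note shows. Statements on the series, on what has been measured and on what is new or still open speak of the compounds shown alone.

Three analogues on one shared core have been measured in an assay on isolated protein for inhibition of protein kinase C zeta type (Homo sapiens), with stated times of 1 h and 2.5 min, tested at 30 uM; a higher number here means more inhibition at the concentration tested (going by the name of the read-out), a lower number less inhibition. Compound 1 `CCNC(=O)c1c(-c2ccc(OC)c(OC)c2)csc1N` gives 50%. Compound 2 `CCOC(=O)c1c(-c2ccc(C)cc2)csc1N` gives 80%, the highest of the three numbers; compound 1 sits lower by more than the scatter, and compound 3 `CCOC(=O)c1c(-c2cccc(C(F)(F)F)c2)csc1N`, which gives 30%, lies lower still. Among the measured compounds shown here, compound 3 is the only measured analogue carrying a trifluoromethyl group on its aromatic ring, and its number is the lowest of the three.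

Compound 4 `CCOC(=O)c1c(-c2ccc(C(F)(F)F)cc2)csc1N` has not been measured. It differs from compound 2 in one place: trifluoromethyl in place of methyl on an aromatic carbon. For the measured compounds named here, no pair of measured compounds differs in exactly this way, so the step has no direct precedent within the set. Going by the values given here, the one pointer is that compound 3 carries the same group and gives 30%, well below compound 2. The expected step is a number 35 percentage points lower from compound 2 to compound 4 (beyond the scatter), downward and beyond the scatter, given that compound 3 gives 30%. Compound 4 is estimated at 45%, with a range from 15% to 75%.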

Compound 4, a percentage reported as inhibition, at one concentration (the size of the read-out at that concentration, not a potency): 16%
Compound 4: middle estimate off by 29 percentage points, on the high side; measured number inside the range.
By their numbers in this assay, from the lowest: compound 4; then compound 3; then compound 1; then compound 2.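

In this assay, among the compounds shown here, putting trifluoromethyl in place of methyl on an aromatic carbon, para to a large group, gives a number 64 percentage points lower from compound 2 to compound 4 (beyond the scatter) as the only change, the first one-place step available. At this position, the level of inhibition therefore depends strongly on which of these two groups is present, and the higher number belongs to methyl. Nothing shown gives a reason for this large drop.

On these data alone, only methyl and trifluoromethyl can be compared at this carbon, so it remains open whether a chlorine atom, a methoxy group, an amine or a longer chain such as ethyl would stay nearer compound 2 or compound 4. As far as these compounds go, it is also open whether the same exchange would have a similar effect with an ethyl amide in place of the ethyl ester.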